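A few compounds are considered here, and "the series" means these few. Any claim that something is new, unique, unknown or untested is made for them only; others in the source may bear on it.

Measured so far in a physicochemical assay for lipophilicity; a lower number here means a more polar compound, a higher number a more lipophilic compound:

compound 1 `Cc1cn(C2CC(N=[N+]=[N-])C(COC(=O)NCCCC(=O)OC(C)(C)C)O2)c(=O)[nH]c1=O` gives 0.88
compound 2 `Cc1cn(C2CC(N=[N+]=[N-])C(COC(=O)OCCCCO)O2)c(=O)[nH]c1=O` gives -0.68
compound 3 `Cc1cn(C2CC(N=[N+]=[N-])C(COC(=O)CCCO)O2)c(=O)[nH]c1=O` gives -0.95

Compound 3, at -0.95, lies within the scatter of compound 2. Its gap to compound 1 lies well beyond the scatter, with compound 1 the higher number of the two.

Compound 4 `Cc1cn(C2CC(N=[N+]=[N-])C(COC(=O)OCCO)O2)c(=O)[nH]c1=O` has not yet been measured. It differs from compound 3 as follows: 2-hydroxyethoxy in place of 3-hydroxypropyl on a carbonyl carbon. In words, 2-hydroxyethoxy stands in place of 3-hydroxypropyl on a carbonyl carbon.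

Among the measured compounds shown here, only one measured step falls at this place: a number 0.27 log units lower from compound 2 to compound 3 (within the scatter), with 3-hydroxypropyl in place of 4-hydroxybutoxy on a carbonyl carbon. For the measured compounds named here, compound 1 offers no such step. The new group in compound 4 is a shorter chain of the same kind as the 4-hydroxybutoxy of compound 2, which gives -0.68. Going by the values given here, with one small step as the only guide, a similarly small change is expected in this assay, pointing slightly downward and probably not leaving the scatter. The expected change is a number 0.25 log units lower from compound 3 to compound 4 (within the scatter). The estimate for compound 4 is -1.2, with an expected range from -1.6 to -0.85.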

Compound 4, partition coefficient: -1.2
For compound 4 middle estimate and measured number coincide at the digits printed; low and high end bracket the measured number.
By their numbers in this assay, from the lowest: compounds 4, 3 and 2 (each within the scatter of the next, the first and the last beyond it); then compound 1.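

In this assay, among the compounds shown here, the exchange of 3-hydroxypropyl for 2-hydroxyethoxy on a carbonyl carbon gives a number 0.25 log units lower from compound 3 to compound 4 (within the scatter), while the comparison of the two hydroxyalkoxy chains gives a number 0.52 log units lower from compound 2 to compound 4 (beyond the scatter), the first step at this position to pass the scatter. Compound 3 lies within the scatter of both compound 2 and compound 4, so two steps that cannot be told apart individually span a gap that can, and the 2-hydroxyethoxy and 4-hydroxybutoxy groups are clearly separated in this read-out. Nothing available here explains this difference between the chains.

The compounds shown leave open whether a longer chain than 4-hydroxybutoxy would extend the same direction, since the pattern rests on compound 2, compound 3 and compound 4 alone. They also leave open how an amine or a carboxylic acid would read in place of the terminal hydroxy group on a chain of the same length, with the rest of the structure unchanged.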